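Cytotoxicity notes on the series: step from compound 3 to compound 4

The compounds below may be only part of what the source reports. "The series", "measured", "known", "first", "only" and "open" are said of these compounds alone.

Measured so far in a functional assay on CCRF-CEM cells (Homo sapiens); on this read-out higher numbers stand for lower toxicity in this test and lower numbers for higher toxicity in this test:
compound 1 `COC(=O)NC1=CS(=O)(=O)O[C@@]12[C@@H](CO[Si](C)(C)C(C)(C)C)O[C@@H](n1cc(C)c(=O)n(C)c1=O)[C@@H]2O[Si](C)(C)C(C)(C)C` — compound 1 gives 30700 nM
compound 2 `Cc1cn([C@@H]2O[C@H](CO[Si](C)(C)C(C)(C)C)[C@@]3(OS(=O)(=O)C=C3NC(=O)NC(=O)c3ccccc3)[C@H]2O[Si](C)(C)C(C)(C)C)c(=O)n(C)c1=O` — compound 2 gives 2290 nM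
compound 3 `Cc1cn([C@@H]2O[C@H](CO[Si](C)(C)C(C)(C)C)[C@@]3(OS(=O)(=O)C=C3NCC(=O)O)[C@H]2O[Si](C)(C)C(C)(C)C)c(=O)n(C)c1=O` — compound 3 gives 65000 nM

Compound 3 stands highest of the three numbers: a 2.1-fold higher number from compound 1 to compound 3 (0.33 log units; beyond the scatter) and a 28-fold higher number from compound 2 to compound 3 (1.45 log units; beyond the scatter), both beyond the scatter, while a 13-fold lower number from compound 1 to compound 2 (1.13 log units; beyond the scatter).

Compound 4 `Cc1cn([C@@H]2O[C@H](CO[Si](C)(C)C(C)(C)C)[C@@]3(OS(=O)(=O)C=C3NCC(N)=O)[C@H]2O[Si](C)(C)C(C)(C)C)c(=O)n(C)c1=O` differs from compound 3 as follows: amino in place of hydroxy on a carbonyl carbon. Going by the values given here, no measured step covers this exchange; the steps seen concern the whole substituent on the amine nitrogen and were modest to large. With the carbamoylmethyl chain kept and only the terminal group changed, a small downward step within or near the scatter is expected, a 1.6-fold lower number from compound 3 to compound 4 (0.21 log units; within the scatter), so compound 4 is estimated at 40000 nM, range 15000 nM to 100000 nM.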

Compound 4, half-maximal cytotoxic concentration: 14600 nM
Compound 4: middle estimate off by 2.7-fold (0.44 log units), on the high side, and the stated range ends above it.
By their numbers in this assay, from the lowest: compound 2; then compound 4; then compound 1; then compound 3.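

In this assay, the terminal group on the carbonyl carbon of the chain matters by itself: amino in place of hydroxy gives a step beyond the scatter (a 4.5-fold lower number from compound 3 to compound 4 (0.65 log units; beyond the scatter)). Carbamoylmethyl on the amine nitrogen also reads below methoxycarbonyl (a 2.1-fold lower number from compound 1 to compound 4 (0.32 log units; beyond the scatter)) but above benzoylcarbamoyl (a 6.4-fold higher number from compound 2 to compound 4 (0.80 log units; beyond the scatter)). Nothing available explains these steps.

Open, from the compounds shown here alone, is whether a methyl ester or a methylamide at the chain end would follow the amide or the acid. Also open, going by these compounds, is how a longer chain or a terminal amine would read.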